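Sulfonyl aryl variation in an orexin-2 antagonist series

This account rests on a few compounds, and the source may have more. Where it says the series, first, only, none or still open, it means among the compounds named here.

Compound 1 `CCN(CC)C(=O)CN(c1ccc(C)cc1)S(=O)(=O)c1cccc(C)c1` and compound 2 `CCN(CC)C(=O)CN(c1ccc(C)cc1)S(=O)(=O)c1ccc(C#N)cc1` share one core and differ only in the aryl group on the sulfonyl sulfur. In a functional assay on CHO cells for inhibition of Orexin receptor type 2 (Homo sapiens), read by FLIPR and calcium flux (a lower number here means a stronger inhibitor, a higher number a weaker inhibitor), compound 1 gives 60 nM, and compound 2 gives 1190 nM. Within the data shown here, compound 2 thus holds the highest of the two numbers so far, with compound 1 as its nearest neighbour a clear step below. Among the measured compounds shown here, the only step recorded is a 20-fold higher number from compound 1 to compound 2 (1.30 log units; beyond the scatter), a 4-cyanophenyl in place of 3-methylphenyl on the sulfonyl sulfur.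

Compound 3 `CCN(CC)C(=O)CN(c1ccc(C)cc1)S(=O)(=O)c1ccc(OC)cc1` takes the same core and alters the group on this ring: methoxy in place of cyano on an aromatic carbon. For the measured compounds named here, no measured pair shows a cyano exchanged for a methoxy, so the 1>2 step is the only guide; it shows that the substituent on this ring can shift the number by a large amount. Since the cyano variant stands at the weak end, a change away from it is expected to give a lower number, of moderate size: a 3.0-fold lower number from compound 2 to compound 3 (0.47 log units; beyond the scatter). Compound 3 is therefore estimated at 400 nM, with a range from 100 nM to 1600 nM.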

Compound 3, half-maximal inhibitory concentration: 661 nM
Beside the measured number, compound 3's estimate is 1.7-fold (0.22 log units) below it; low and high end bracket the measured number.
By their numbers in this assay, from the lowest: compound 1; then compounds 3 and 2 (each within the scatter of the next).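

In this assay, the exchange of cyano for methoxy on an aromatic carbon, para to a large group, gives a step that lies within the scatter (a 1.8-fold lower number from compound 2 to compound 3 (0.26 log units; within the scatter)), so the 4-cyanophenyl and 4-methoxyphenyl groups are not told apart by these numbers. The large step first seen with the cyano group therefore does not belong to that group alone, since the 4-methoxyphenyl group of compound 3 also stands well apart from the 3-methylphenyl group of compound 1 (an 11-fold higher number from compound 1 to compound 3 (1.04 log units; beyond the scatter)). No measurement at hand accounts for this gap.

Compound 1 differs from both compound 2 and compound 3 in the substituent and also in where it sits on the ring, so the compounds shown cannot say which of these two differences carries the gap. A methyl group para to a large group would separate the two, and the compounds shown also leave open how an amine or a carboxylic acid at that place would read in this assay; only two substituents are shown there so far.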